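The compounds below may be only part of what the source reports. "The series", "measured", "known", "first", "only" and "open" are said of these compounds alone.

The three measured compounds share one core and differ only in the arm that carries the selenocyanate. In a functional assay on A549 cells (Homo sapiens) for inhibition, read by MTT assay, with a stated time of 48 h (on this read-out lower numbers stand for stronger inhibition and higher numbers for weaker inhibition), compound 1 `COc1ccc(N(C)c2nc(C)nc3ccccc23)cc1C(=O)NCC[Se]C#N` gives 187 nM. Compound 2 `COc1ccc(N(C)c2nc(C)nc3ccccc23)cc1C(=O)OCCCCC[Se]C#N` gives 592 nM in this assay, and compound 3 `COc1ccc(N(C)c2nc(C)nc3ccccc23)cc1C(=O)OCC[Se]C#N` gives 353 nM. Compound 3 thus holds the second highest of the three numbers, but it sits within the scatter of both neighbours: a 1.7-fold lower number from compound 2 to compound 3 (0.22 log units; within the scatter) and a 1.9-fold higher number from compound 1 to compound 3 (0.28 log units; within the scatter). For the measured compounds named here, the only step beyond the scatter is a 3.2-fold higher number from compound 1 to compound 2 (0.50 log units; beyond the scatter), a modest one.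

Compound 4 `COc1ccc(N(C)c2nc(C)nc3ccccc23)cc1C[Se]C#N` is reached from compound 3 by a change at the aromatic ring itself: a group of 4 heavy atoms (2 carbon, 1 nitrogen, 1 selenium; no ring) in place of a group of 8 heavy atoms (4 carbon, 1 nitrogen, 2 oxygen, 1 selenium; no ring), on an aromatic carbon. Going by the values given here, no measured step removes the carbonyl linkage; the steps seen all concern the arm beyond it and stayed small, so they bear on this change only loosely. The author therefore expects as the estimated step of a 1.1-fold higher number from compound 3 to compound 4 (0.05 log units; within the scatter), and keeps the range around it wide. Compound 4 is estimated at 400 nM, between 150 nM and 1100 nM.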

Compound 4, half-maximal inhibitory concentration: 98 nM
Compound 4: the middle estimate sits 4.1-fold (0.61 log units) above what was measured; the whole stated range lies above it.
By their numbers in this assay, from the lowest: compounds 4, 1, 3 and 2 (each within the scatter of the next, the first and the last beyond it).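

In this assay, for the compounds shown here, this is the first change at the aromatic carbon ortho to the methoxy group itself, and removing the whole ester arm, carbonyl included, in favour of the smaller selenium-bearing group gives a 3.6-fold lower number from compound 3 to compound 4 (0.56 log units; beyond the scatter). The earlier steps had only altered the arm beyond the carbonyl, so the result shows that, among these compounds, the carbonyl linkage can go without the number rising. Set against the amide, the same kind of replacement gives a 1.9-fold lower number from compound 1 to compound 4 (0.28 log units; within the scatter), so compound 4 and compound 1 cannot be told apart here, and nothing measured on these compounds explains the step from the ester.

The compounds shown leave open how a longer chain carrying the selenocyanate on this aromatic carbon would read. They also leave open whether a thiocyanate, with sulfur in place of selenium, would match compound 4.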